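This account rests on a few compounds, and the source may have more. Where it says the series, first, only, none or still open, it means among the compounds named here.

Working notes on the series. Compound 1 `CCc1nc(N)c2nc(O)n(Cc3ccccc3)c2n1` carries an ethyl on the aromatic carbon of the shared core; in a functional assay (spleen, spleen) for activation, with Mus musculus as the target (a lower number here means that less compound is needed, a higher number that more compound is needed for the effect), compound 1 gives 1 uM. Compound 2 `CCCNc1nc(N)c2nc(O)n(Cc3ccccc3)c2n1` carries propylamino at the same place and in this assay compound 2 gives 0.1 uM. Going by the values given here, the only step measured so far, a 10-fold lower number from compound 1 to compound 2 (1.00 log units; beyond the scatter), is the one that separates the two. Among the compounds with values here, on the numbers so far compound 2 stands lowest, with compound 1 the nearest and the only other point.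

Compound 3 `CCCC[S+]([O-])c1nc(N)c2nc(O)n(Cc3ccccc3)c2n1` is the next one to be measured. The change from compound 2 to compound 3 is a group of 6 heavy atoms (4 carbon, 1 oxygen, 1 sulfur; no ring) in place of a group of 4 heavy atoms (3 carbon, 1 nitrogen; no ring), on an aromatic carbon. The entering group has no common name; the hydrogen-bond donor of propylamino is gone, one hydrogen-bond acceptor remains. Within the data shown here, no measured step covers this exchange; the step of a 10-fold lower number from compound 1 to compound 2 (1.00 log units; beyond the scatter) shows only that the propylamino position is sensitive to what sits there. Compound 3 is therefore expected at 0.5 uM, within 0.1 uM to 3 uM, a step of a 5.0-fold higher number from compound 2 to compound 3 (0.70 log units; beyond the scatter) being the estimate.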

Compound 3, minimum effective concentration: 0.01 uM
Estimate against measurement, compound 3: 50-fold (1.70 log units) above; the measured number lies below the stated range.
By their numbers in this assay, from the lowest: compound 3; then compound 2; then compound 1.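

In this assay the aromatic carbon between two ring nitrogen atoms still has room for a lower number after propylamino, with a 10-fold lower number from compound 2 to compound 3 (1.00 log units; beyond the scatter) and, over the whole series, a 100-fold lower number from compound 1 to compound 3 (2.00 log units; beyond the scatter). The hydrogen-bond donor of propylamino is therefore not needed for a low number at this position: it is gone in compound 3, which stands lowest of the three. Nothing measured on these compounds bears on why the entering group gives this result.

The compounds shown do not separate the part played by the oxygen on sulfur from that of the longer chain: a butylthio group and a butylamino group would each address one of these. From the compounds shown here alone, how far the trend runs is also open, as a butylsulfonyl group or a longer chain on the sulfur could still go either way.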